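The compounds below may be only part of what the source reports. "The series", "measured", "known", "first", "only" and "open" are said of these compounds alone.

In a functional assay on K562 cells (Homo sapiens) for cytotoxicity, read by fluorescence, with a stated time of 72 h (on this read-out higher numbers stand for weaker inhibition and lower numbers for stronger inhibition), compound 1 `Nc1nn(C(=O)c2ccc([N+](=O)[O-])cc2)c(N)c1/N=N/c1ccc(O)cc1` gives > 25000 nM, which is a limit of the assay and not a number. Among the compounds with values here, compound 2 `Cn1nc(N)c(/N=N/c2ccc(O)cc2)c1N` gives 98500 nM, the only true number so far, with nothing measured to rank it against. Compound 3 `CC(=O)n1nc(N)c(/N=N/c2ccc(O)cc2)c1N` differs from compound 2 in one place: acetyl in place of methyl on an aromatic nitrogen. Within the data shown here, no measured step bears on this change, and no shift beyond the usual scatter is expected in this assay. The expected step is a 1.3-fold lower number from compound 2 to compound 3 (0.12 log units; within the scatter). For compound 3 the estimated value is 75000 nM, with an expected range of 25000 nM to 200000 nM.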

Compound 3, half-maximal inhibitory concentration: 64900 nM
Estimate against measurement, compound 3: 1.2-fold (0.06 log units) above; the measured number falls inside the stated range.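

In this assay, within the data shown here, acetyl in place of methyl on the aromatic nitrogen gives a 1.5-fold lower number from compound 2 to compound 3 (0.18 log units; within the scatter), the first step between two true numbers; on this pair, the position tolerates the exchange without a shift beyond the scatter. Compound 1 gives > 25000 nM, a limit and not a number, so its step to compound 3 cannot be read: the limit of > 25000 nM in this assay, at which 1 of the 3 values shown sits.

Open, on these data alone, is whether a longer chain such as butyl, or a chain ending in an amine or a carboxylic acid, on this nitrogen would move the number beyond the scatter.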